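The source may report more compounds than this note shows. Statements on the series, on what has been measured and on what is new or still open speak of the compounds shown alone.

Measured in a physicochemical assay for solubility, at pH 7.4; a higher number here means a more soluble compound, a lower number a less soluble compound:
- compound 1 `CCCCNc1nc(N)c2nc(O)n(Cc3ccc(C)cc3)c2n1`: < 1000 ug/mL, a limit of the assay and not a number
- compound 2 `CCCCNc1nc(N)c2[nH]c(=O)n(Cc3ccc(N(C)C)cc3)c2n1`: 98000 ug/mL
- compound 3 `CCCCNc1nc(N)c2[nH]c(=O)n(Cc3ccc(N4CCCCC4)cc3)c2n1`: 19000 ug/mL

Compound 3, at 19000 ug/mL, holds the lower of the two actual numbers in this assay. For the measured compounds named here, the only other number is one measured step away: a 5.2-fold lower number from compound 2 to compound 3 (0.71 log units; beyond the scatter). That modest step lies beyond the scatter.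

Compound 4 `CCCCNc1nc(N)c2[nH]c(=O)n(Cc3ccc(N4CCN(C)CC4)cc3)c2n1` has not yet been measured. It carries 4-methylpiperazin-1-yl in place of piperidin-1-yl on an aromatic carbon, para to a large group: 4-methylpiperazin-1-yl in place of piperidin-1-yl on an aromatic carbon. Going by the values given here, only one measured step bears on this change, since it alone swaps the group at the same place: a 5.2-fold lower number from compound 2 to compound 3 (0.71 log units; beyond the scatter). It gives a guide to size but not to direction, as it involves a different pair of groups. A step of similar modest size is expected, and the expected direction is upward, with the entering group counted above as the one with the second ring nitrogen.

For compound 4 the estimated value is 60000 ug/mL, with an expected range from 18000 ug/mL to 200000 ug/mL. The estimate means, as an expectation, a 3.2-fold higher number from compound 3 to compound 4 (0.50 log units; beyond the scatter).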

Compound 4, solubility: 108000 ug/mL
Estimate against measurement, compound 4: 1.8-fold (0.26 log units) below, within the range that was stated.
By their numbers in this assay, from the lowest: compound 3; then compounds 2 and 4 (each within the scatter of the next). At a limit, below all of these: compound 1.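

In this assay, for the compounds shown here, the earlier compounds showed only a fall when a ring replaced dimethylamino at this place, and this change shows that a ring there need not lower the number (a 5.7-fold higher number from compound 3 to compound 4 (0.75 log units; beyond the scatter)). Compound 4 also stands level with the open-chain group of compound 2 (a 1.1-fold higher number from compound 2 to compound 4 (0.04 log units; within the scatter)), so the presence of a six-membered non-aromatic ring does not by itself settle the number, as compound 3 and compound 4 both carry one. Nothing in the data gives a cause for this step.

The compounds shown do not separate the second ring nitrogen from the methyl group on it, since 4-methylpiperazin-1-yl brings both at once. Piperazin-1-yl without the methyl and morpholin-4-yl, with oxygen in that ring place, would each test one of these alone.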